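The source may hold more compounds than are shown below. What is called first, only, known or untested is meant among the compounds shown, and "the series" means these compounds.

In an ADME assay on Vero cells (Chlorocebus sabaeus) for cytotoxicity, read by resazurin assay, with a stated time of 72 h (a higher number here means a weaker inhibitor, a lower number a stronger inhibitor), three compounds have been measured. Compound 1 (`Cc1ccc(C(=O)CCN2CCN(c3ccc(C(F)(F)F)cc3)CC2)cc1`) gives 140000 nM and compound 2 (`COc1ccc(C(=O)CCN2CCN(c3ccc(Cl)cc3)CC2)cc1OC`) gives 185000 nM on this scale. Compound 3 (`COc1ccccc1N1CCN(CCC(=O)c2ccc(F)cc2)CC1`) gives 24000 nM as the lowest of the three numbers, and its gap to each of the other two lies beyond the scatter.

The next compound to be measured is compound 4 (`COc1ccc(N2CCN(CCC(=O)c3ccc(F)cc3)CC2)cc1`). It has the same atoms as compound 3, joined differently, with 4-methoxyphenyl in place of 2-methoxyphenyl on an amine nitrogen in a ring. For the measured compounds named here, no two measured compounds differ in one place only, so the effect of this swap has not been seen directly. Going by the values given here, the only guide is a loose one. Among the measured compounds, only compound 3 carries the 2-methoxyphenyl group, and it reads 24000 nM in this assay while the two without that group read higher, although they also differ elsewhere. A moderate rise in the number is therefore expected, probably beyond the scatter but with real doubt. The expected change is a 2.1-fold higher number from compound 3 to compound 4 (0.32 log units; beyond the scatter) in this estimate. For compound 4 the estimated value is 50000 nM with an expected range from 18000 nM to 150000 nM in this assay as the measurement that is still to come.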

Compound 4, half-maximal inhibitory concentration: 31900 nM
Estimate against measurement, compound 4: 1.6-fold (0.20 log units) above; the measured number falls inside the stated range.
By their numbers in this assay, from the lowest: compounds 3 and 4 (each within the scatter of the next); then compounds 1 and 2 (each within the scatter of the next).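

In this assay, 4-methoxyphenyl in place of 2-methoxyphenyl on the amine nitrogen in the ring gives a 1.3-fold higher number from compound 3 to compound 4 (0.12 log units; within the scatter), and this is the only pair shown that differs in one place. The two groups match in heavy atoms, in their aromatic ring and in their counts of donors and acceptors, so the step tests only how the same atoms are joined, and at this place the change leaves the number within the scatter, with no order between the two compounds. No measurement shown offers an explanation for this result.

The compounds shown leave open whether a hydroxyl, an amine or a carboxylic acid in place of the methoxy would leave the number just as unchanged at this place, as the only change seen here keeps the same atoms. They also leave open whether the same swap would stay within the scatter on a different remainder of the molecule, as compound 3 and compound 4 share everything else in their structures.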